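A Sulfonamide Series Examined for Intestinal Cell Permeability

The compounds below may be only part of what the source reports. "The series", "measured", "known", "first", "only" and "open" are said of these compounds alone.

Measured compounds:
Compound 1, `CCCC(=O)N1CCC(CN(C2Cc3cc(C#N)ccc3N(Cc3cncn3C)C2)S(=O)(=O)c2ccccn2)CC1`, gives 0.5 10^-6 cm/s in an ADME assay on Caco-2 cells (Homo sapiens) for permeability, in the apical to basolateral direction; on this read-out lower numbers stand for lower permeability and higher numbers for higher permeability.
Compound 2, `CC(C)OC(=O)N1CCC(CN(C2Cc3cc(C#N)ccc3N(Cc3cncn3C)C2)S(=O)(=O)c2ccccn2)CC1`, gives 1 10^-6 cm/s in this assay.
Compound 3, `Cc1noc(C)c1CN(C1Cc2cc(C#N)ccc2N(Cc2cncn2C)C1)S(=O)(=O)c1ccccn1`, gives 8 10^-6 cm/s in this assay.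

Compound 2 holds the second highest of the three numbers. Its nearest neighbour is compound 1, separated by a 2.0-fold higher number from compound 1 to compound 2 (0.30 log units; within the scatter), whereas compound 3 lies furthest away, separated by an 8.0-fold higher number from compound 2 to compound 3 (0.90 log units; beyond the scatter).

The step to compound 4, `Cn1cncc1CN1CC(N(CC2CCN(C(=O)CC(F)(F)F)CC2)S(=O)(=O)c2ccccn2)Cc2cc(C#N)ccc21`, alters the carbonyl substituent on the piperidine nitrogen: 2,2,2-trifluoroethyl in place of isopropoxy on a carbonyl carbon.

Among the measured compounds shown here, of the measured steps, the one between compound 1 and compound 2 bears most directly on this change because it too swaps the group on that carbonyl carbon and reads a 2.0-fold higher number from compound 1 to compound 2 (0.30 log units; within the scatter). The two larger steps, a 16-fold higher number from compound 1 to compound 3 (1.20 log units; beyond the scatter) and an 8.0-fold higher number from compound 2 to compound 3 (0.90 log units; beyond the scatter), replace the entire piperidinyl portion with a small heteroaryl group and therefore inform less about a change confined to the carbonyl substituent.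

On this basis no step beyond the scatter is expected in this assay for compound 4, and the estimated step from compound 2 is a 1.1-fold lower number from compound 2 to compound 4 (0.05 log units; within the scatter). The estimate for compound 4 is 0.9 10^-6 cm/s, with a range from 0.3 10^-6 cm/s to 2.5 10^-6 cm/s.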

Compound 4, apparent permeability: 0.5 10^-6 cm/s
The estimate for compound 4 lay 1.8-fold (0.26 log units) above the measured number; low and high end bracket the measured number.
By their numbers in this assay, from the lowest: compounds 1, 4 and 2 (each within the scatter of the next); then compound 3.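

In this assay, the place on a carbonyl carbon whose other neighbour is an amide-type nitrogen in a ring now carries three different groups, and all of their steps stay within the scatter: 2,2,2-trifluoroethyl in place of isopropoxy gives a 2.0-fold lower number from compound 2 to compound 4 (0.30 log units; within the scatter), and trifluoromethyl in place of ethyl on the saturated chain carbon bound to that carbonyl carbon gives no change at the digits printed from compound 1 to compound 4 (within the scatter). Among the compounds shown here, the earlier compounds offered only one swap at this carbonyl carbon, whereas compound 4 adds a fluorine-bearing group with no hydrogen-bond acceptor, so across these three compounds no change here reaches the size of the replacement of the whole piperidinyl portion, as in an 8.0-fold higher number from compound 2 to compound 3 (0.90 log units; beyond the scatter). Nothing in the available data accounts for these close readings.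

On these data alone, it remains open whether a different kind of group on this carbonyl carbon, such as an amine, a carboxylic acid or a longer chain, would stay within the scatter of these three compounds. The compounds shown also leave open whether the 2,2,2-trifluoroethyl for isopropoxy swap would read the same on a different sulfonamide substituent or core.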